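A Third Aryl Swap on the Ring Nitrogen

This account rests on a few compounds, and the source may have more. Where it says the series, first, only, none or still open, it means among the compounds named here.

Compound 1 `Oc1cc(C(F)(F)F)ccc1-c1nc(-c2ccccc2O)n(-c2ccc(Cl)cc2)n1` gives 87.3% in a functional assay on PC-12 cells (Rattus norvegicus) for cytotoxicity, read by MTT assay, with stated times of 2 h and 24 h, tested at 5 uM; on this read-out lower numbers stand for a weaker effect and higher numbers for a stronger effect at the one concentration tested.
Compound 2 `Oc1cc(C(F)(F)F)ccc1-c1nc(-c2ccccc2O)n(-c2ccccc2F)n1` gives 86.6% in this assay.
Compound 3 `Oc1cc(C(F)(F)F)ccc1-c1nc(-c2ccccc2O)n(-c2ccccc2C(F)(F)F)n1` gives 80% in this assay.

Compound 3 carries the lowest of the three numbers, yet the change from compound 1 is a number 7.3 percentage points lower from compound 1 to compound 3 (within the scatter) and that from compound 2 is a number 6.6 percentage points lower from compound 2 to compound 3 (within the scatter), so the three sit together. Compound 4 `COc1cccc(-n2nc(-c3ccc(C(F)(F)F)cc3O)nc2-c2ccccc2O)c1` differs from compound 3 by 3-methoxyphenyl in place of 2-(trifluoromethyl)phenyl on an aromatic nitrogen. The two earlier steps that changed the group on this same aromatic nitrogen, a number 0.7 percentage points lower from compound 1 to compound 2 (within the scatter) and a number 7.3 percentage points lower from compound 1 to compound 3 (within the scatter), stayed within the scatter, so compound 4 is expected to show no step beyond the scatter in this assay, about a number 2 percentage points higher from compound 3 to compound 4 (within the scatter). Compound 4 is therefore estimated at 82%, between 72% and 92%.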

Compound 4, a percentage reported as activity, at one concentration (the size of the read-out at that concentration, not a potency): 96.8%
Compound 4: middle estimate off by 14.8 percentage points, on the low side; measured number outside the range, above it.
By their numbers in this assay, from the lowest: compounds 3, 2, 1 and 4 (each within the scatter of the next, the first and the last beyond it).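

In this assay, among these compounds, the group on this aromatic nitrogen now makes a difference: with a number 16.8 percentage points higher from compound 3 to compound 4 (beyond the scatter) and a number 10.2 percentage points higher from compound 2 to compound 4 (beyond the scatter) as the first steps beyond the scatter at this position, 3-methoxyphenyl separates from both 2-(trifluoromethyl)phenyl and 2-fluorophenyl. It does not separate from 4-chlorophenyl, with a number 9.5 percentage points higher from compound 1 to compound 4 (within the scatter) as the step there. No measurement at hand accounts for these steps.

On these data alone, whether they belong to the methoxy group itself or to where it sits on the phenyl ring stays open, as does what an amine or a carboxylic acid on that phenyl ring would give.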